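A Methoxy Swap on a Hydroxy Compound

This account rests on a few compounds, and the source may have more. Where it says the series, first, only, none or still open, it means among the compounds named here.

In a functional assay on ZR-75-1 cells (Homo sapiens) for inhibition, read by sulforhodamine B assay (a lower number here means a stronger inhibitor of growth, a higher number a weaker inhibitor of growth), compound 1 `c1ccc(-c2ccc(-c3ccc(-c4nc5ccccc5[nH]4)cc3)cc2)cc1` gives 100000 nM and compound 2 `Fc1ccc(-c2ccc(-c3ccc(-c4nc5ccccc5[nH]4)cc3)cc2)cc1` gives 100000 nM. Compound 3 `Oc1cccc2[nH]c(-c3ccc(-c4ccc(-c5ccc(F)cc5)cc4)cc3)nc12` has the lowest number of the three, at 6320 nM. Adding a hydroxy group gave a 16-fold lower number from compound 2 to compound 3 (1.20 log units; beyond the scatter).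

Compound 4 `COc1ccc(-c2ccc(-c3ccc(-c4nc5c(O)cccc5[nH]4)cc3)cc2)cc1` keeps that hydroxy but differs at one place: methoxy in place of fluoro on an aromatic carbon. This is methoxy in place of fluoro on an aromatic carbon. The closest evidence is fluoro in place of hydrogen at that same place, which gave no change at the digits printed from compound 1 to compound 2 (within the scatter). The large hydroxy step happened elsewhere, so little change is expected here: a 1.1-fold lower number from compound 3 to compound 4 (0.02 log units; within the scatter) is the expected step, none beyond the scatter. For compound 4, the estimated value is 6000 nM, with an expected range of 1800 nM to 20000 nM.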

Compound 4, concentration for 50% growth inhibition: 8200 nM
Estimate against measurement, compound 4: 1.4-fold (0.14 log units) below, within the range that was stated.
By their numbers in this assay, from the lowest: compounds 3 and 4 (each within the scatter of the next); then compounds 1 and 2 (each within the scatter of the next).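

Replacing 4-fluorophenyl with 4-methoxyphenyl gave a 1.3-fold higher number from compound 3 to compound 4 (0.11 log units; within the scatter) in this assay. The earlier fluoro step at this position was seen only without the hydroxy group, whereas this one shows that, with the hydroxy present, a group with more heavy atoms and a hydrogen-bond acceptor still leaves the number within the scatter. No available evidence bears on the reason for this result.

From the compounds shown here alone, whether an amine, a carboxylic acid or a longer chain at this position would also leave the number within the scatter remains open.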